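Swapping methyl for chloro on the best compound so far

This account rests on a few compounds, and the source may have more. Where it says the series, first, only, none or still open, it means among the compounds named here.

In a functional assay on SGC-7901 cells (Homo sapiens) for antiproliferative activity, read by MTT assay, with a stated time of 72 h (a higher number here means a weaker inhibitor, a lower number a stronger inhibitor), compound 3 `COc1cc(-n2cnc3ccc(-c4ccc(C)cc4)cc32)cc(OC)c1OC` gives 200 nM as the lowest of three numbers. Compound 1 `COc1cc(-n2cnc3ccc(-c4cccc(F)c4)cc32)cc(OC)c1OC` gives 2490 nM and compound 2 `COc1cc(-n2cnc3ccc(-c4cccc(C)c4C)cc32)cc(OC)c1OC` gives 3040 nM in this assay as well. Compound 4 `COc1cc(-n2cnc3ccc(-c4ccc(Cl)cc4)cc32)cc(OC)c1OC` has not yet been measured. It carries chloro in place of methyl on an aromatic carbon para to a large group. The steps of a 12-fold lower number from compound 1 to compound 3 (1.10 log units; beyond the scatter) and a 15-fold lower number from compound 2 to compound 3 (1.18 log units; beyond the scatter) are both large and beyond the scatter, whereas a 1.2-fold higher number from compound 1 to compound 2 (0.09 log units; within the scatter) stays within it. Among the measured compounds shown here, each of these steps replaces the whole substituted phenyl, and no measured step exchanges methyl for chloro alone. They therefore give only indirect guidance. Since compound 4 keeps the 4-substituted phenyl pattern of compound 3 at 200 nM and only the group itself changes, no step beyond the scatter is expected. From the compounds shown here alone, the estimated step is a 1.3-fold higher number from compound 3 to compound 4 (0.10 log units; within the scatter) and its direction remains open. For compound 4 the estimated value is 250 nM with an expected range from 80 nM to 800 nM for now.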

Compound 4, half-maximal inhibitory concentration: 1270 nM
Beside the measured number, compound 4's estimate is 5.1-fold (0.71 log units) below it; measured number outside the range, above it.
By their numbers in this assay, from the lowest: compound 3; then compounds 4, 1 and 2 (each within the scatter of the next, the first and the last beyond it).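

Taken alone, the exchange of methyl for chloro on an aromatic carbon para to a large group gives a 6.4-fold higher number from compound 3 to compound 4 (0.80 log units; beyond the scatter) in this assay and shows that this position separates these two small groups, which the earlier steps, each replacing a whole substituted phenyl, could not show. The 4-substituted pattern alone therefore does not secure the low number of compound 3, since 4-chlorophenyl gives a 2.0-fold lower number from compound 1 to compound 4 (0.29 log units; within the scatter) when it replaces 3-fluorophenyl and a 2.4-fold lower number from compound 2 to compound 4 (0.38 log units; beyond the scatter) when it replaces 2,3-dimethylphenyl. Nothing available accounts for the difference between methyl and chloro at this position.

From the compounds shown here alone, whether ethyl or an amine at this position would match compound 3 at 200 nM remains open. Going by these compounds, all four compounds share the same core, so it also remains open whether the methyl-to-chloro step would keep its size on a different core.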